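The source may hold more compounds than are shown below. What is called first, only, known or untested is meant among the compounds shown, and "the series" means these compounds.

Compound 1 `O=C(O)C(=O)CC(=O)c1ccc(-c2ccccc2)cc1` gives 1100 nM in an assay on isolated protein (Sus scrofa) for inhibition of 2-Hydroxyacid oxidase 1 (Homo sapiens); a lower number here means a stronger inhibitor, a higher number a weaker inhibitor. Compound 2 `CSc1ccc(-c2ccc(C(=O)CC(=O)C(=O)O)cc2)cc1` carries a methylsulfanyl group where compound 1 has a hydrogen on an aromatic carbon, and in this assay compound 2 gives 160 nM. For the measured compounds named here, that single change yields a 6.9-fold lower number from compound 1 to compound 2 (0.84 log units; beyond the scatter), so compound 2 stands with the lowest number of the two measured compounds, its only neighbour being compound 1.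

Compound 3 `O=C(O)C(=O)CC(=O)c1ccc(-c2ccc(SCc3ccccc3)cc2)cc1` extends compound 2 by phenyl in place of hydrogen on a saturated chain carbon bound to a sulfur. Going by the values given here, the one measured step, from compound 1 to compound 2, concerns attaching the methylsulfanyl group to the ring rather than growing it further out, so it bears only loosely on this change; no measured pair shows what a phenyl on the chain carbon bound to sulfur does. With nothing pointing firmly either way, the expected step in this assay is a 1.3-fold lower number from compound 2 to compound 3 (0.12 log units; within the scatter), a change that would stay within the scatter. Compound 3 is therefore estimated at 120 nM, with a likely range from 35 nM to 450 nM.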

Compound 3, half-maximal inhibitory concentration in the 2-Hydroxyacid oxidase 1 assay: 400 nM
Estimate against measurement, compound 3: 3.3-fold (0.52 log units) below; measured number inside the range.
By their numbers in the 2-Hydroxyacid oxidase 1 assay, from the lowest: compound 2; then compound 3; then compound 1.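

In the 2-Hydroxyacid oxidase 1 assay the phenyl on the saturated chain carbon bound to a sulfur does not add to the gain seen with methylsulfanyl, which is a 6.9-fold lower number from compound 1 to compound 2 (0.84 log units; beyond the scatter): the change from methyl to benzyl gives a 2.5-fold higher number from compound 2 to compound 3 (0.40 log units; beyond the scatter) and so gives part of that gain back. This shows that the chain carbon bound to a sulfur is not a neutral place for growth, which the step from hydrogen to methylsulfanyl alone could not show. Even so, the benzylsulfanyl group still leaves a 2.8-fold lower number from compound 1 to compound 3 (0.44 log units; beyond the scatter), so the larger group keeps a smaller part of the gain over the core of compound 1, and nothing available here accounts for either step. In a physicochemical assay for acid dissociation, compound 2 gives "not determined" (no result reported) and compound 3 gives "not determined" (no result reported), so no comparison can be read there.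

The compounds shown leave open whether the loss belongs to the phenyl itself or to its distance from the sulfur, which a longer chain such as 2-phenylethyl in place of benzyl would speak to. They also leave open how a carboxylic acid or an amine on the added phenyl would read, and whether an oxygen in place of the sulfur would keep the gain of compound 2.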